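Methoxycarbonyl on two cores: solubility

The compounds below may be only part of what the source reports. "The series", "measured", "known", "first", "only" and "open" are said of these compounds alone.

Compound 2 `CN(C)C(=O)c1ccc2cccccc1-2` and compound 3 `CN(C)C(=O)c1cn(C)c2ccccc12` share a dimethylamide but sit on different cores; how the two cores differ is not broken down here. Both carry a limit in a physicochemical assay for solubility, with a stated time of 24 h, at pH 4.5; a lower number here means a less soluble compound, a higher number a more soluble compound. Compound 2 gives > 44 ug/mL, which is a limit. Compound 3 gives > 51 ug/mL, also a limit. Compound 1 `COC(=O)c1ccc2ccc(C(=O)N(C)C)c-2cc1` gives 50 ug/mL, and the change from compound 2 is methoxycarbonyl in place of hydrogen on an aromatic carbon, so a step that the limit leaves unreadable from compound 2 to compound 1 and the limit of > 44 ug/mL in this assay, at which 1 of the 3 values shown sits, leaves its size unreadable.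

Compound 4 `COC(=O)c1ccc2c(C(=O)N(C)C)cn(C)c2c1` is the same kind of change on compound 3, methoxycarbonyl in place of hydrogen on an aromatic carbon: here the place is a six-membered ring, meta and para to a fused ring, not a seven-membered ring. Its size is estimated as an at least 1.4-fold lower number from compound 3 to compound 4 (0.16 log units; that floor lies within the scatter), resting on compound 1 giving 50 ug/mL, and compound 4 is expected at 35 ug/mL, between 10 ug/mL and 120 ug/mL.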

Compound 4, solubility: > 52 ug/mL
Compound 4: a limit, no number; the forecaster's own chance of this, stated with the estimate: 20%; middle value at least 1.4-fold (0.17 log units) from the limit.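

Compound 3 and compound 4 both carry only a limit in this assay, and the step between them cannot be read. From the compounds shown here alone, how much methoxycarbonyl in place of hydrogen on an aromatic carbon changes solubility, on either core, stays open.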